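Lengthening the Carbonyl Substituent of Compound 1

A few compounds are considered here, and "the series" means these few. Any claim that something is new, unique, unknown or untested is made for them only; others in the source may bear on it.

Compound 1 `COC(=O)NS(=O)(=O)c1sc(CC(C)C)cc1-c1cccc(Cn2ccnc2)c1` is the longest-lived of the three measured compounds in an ADME assay on microsomes from liver (Mus musculus) for metabolic stability, read by LC-MS, using NADPH, tested at 1 uM (a lower number here means that the compound disappears faster, a higher number that the compound lasts longer), giving 3.67 h. Compound 2 `CC(C)COC(=O)NS(=O)(=O)c1sc(CC(C)C)cc1-c1cccc(Cn2ccnc2)c1` gives 0.633 h and compound 3 `CC(C)Cc1cc(-c2cccc(Cn3ccnc3)c2)c(S(=O)(=O)NC(=O)OC(C)(C)C)s1` gives 0.467 h. Compound 4 `CCCCCC(=O)NS(=O)(=O)c1sc(CC(C)C)cc1-c1cccc(Cn2ccnc2)c1` differs from compound 1 in one place: pentyl in place of methoxy on a carbonyl carbon. Within the data shown here, no measured step swaps out the methoxy itself, but both steps that enlarge the group on the oxygen side cut the half-life: a 5.8-fold lower number from compound 1 to compound 2 (0.76 log units; beyond the scatter) and a 7.9-fold lower number from compound 1 to compound 3 (0.90 log units; beyond the scatter). Compound 4 brings in a longer chain than either, so a shorter half-life of similar size is expected, a 6.1-fold lower number from compound 1 to compound 4 (0.79 log units; beyond the scatter). Compound 4 is therefore estimated at 0.6 h, with a range from 0.25 h to 1.8 h.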

Compound 4, half-life: 0.148 h
Beside the measured number, compound 4's estimate is 4.1-fold (0.61 log units) above it; measured number outside the range, below it.
By their numbers in this assay, from the lowest: compound 4; then compounds 3 and 2 (each within the scatter of the next); then compound 1.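

Putting pentyl in place of methoxy on the carbonyl carbon gives the largest loss of half-life seen at this position in this assay (a 25-fold lower number from compound 1 to compound 4 (1.39 log units; beyond the scatter)). The loss also goes beyond that of the larger oxygen-linked groups (a 3.2-fold lower number from compound 3 to compound 4 (0.50 log units; beyond the scatter); a 4.3-fold lower number from compound 2 to compound 4 (0.63 log units; beyond the scatter)), leaving compound 4 the shortest-lived of the four. Nothing here bears on the reason for these drops.

From the compounds shown here alone, it remains open whether chain length or the lost oxygen matters more. A methyl group on the same carbonyl carbon and a pentyloxy group would separate the two.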